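Dithioester series: chain length against the assay limit

A few compounds are considered here, and "the series" means these few. Any claim that something is new, unique, unknown or untested is made for them only; others in the source may bear on it.

Three measured compounds share one core. Compound 1 is `CCCCCCCCCCCSC(=S)C1=C(Nc2ccc(Cl)cc2Cl)CC(C)(C)CC1=O`, and in a functional assay on cells (blood, Homo sapiens) for inhibition, read by chemiluminescence, with a stated time of 30 min (a higher number here means a weaker inhibitor, a lower number a stronger inhibitor), compound 1 gives > 100 ug/mL, which is a limit of the assay rather than a number. Compound 2 is `CCCCCCCCCCCSC(=S)C1=C(Nc2ccc(Cl)cc2)CC(C)(C)CC1=O`. In this assay compound 2 gives > 100 ug/mL, again a limit. The step that the two limits leave unreadable from compound 1 to compound 2 is therefore unreadable, and the limit of > 100 ug/mL in this assay, at which 3 of the 3 values shown sit, describes the whole set so far. Compound 3 is `CCCCSC(=S)C1=C(Nc2ccc(Br)cc2)CC(C)(C)CC1=O`. In this assay compound 3 gives > 100 ug/mL, also a limit. Compound 3 thus stands at the ceiling of the measured range with no number of its own.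

Compound 4 is `CCCCCCCCCCCSC(=S)C1=C(Nc2ccc(Br)cc2)CC(C)(C)CC1=O`. The difference from compound 3 is heptyl in place of hydrogen on a saturated chain carbon, four bonds along the chain from a sulfur. Among the measured compounds shown here, no measured step isolates this change. Compound 2 already carries the longer chain that compound 4 would carry and sits at the limit. Compound 3, with the shorter chain, sits at the same limit. Neither chain length has yet produced a readable number. The step that the limit leaves unreadable from compound 3 to compound 4 is expected to stay within the scatter, and the assay will most likely again report only a limit. Compound 4 is expected at 150 ug/mL, within a range of 50 ug/mL to 400 ug/mL.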

Compound 4, half-maximal inhibitory concentration: > 100 ug/mL
Compound 4 was reported as a limit; the forecaster's own chance of this, stated with the estimate: 80%; the middle value is on the limit's open side.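

In this assay compound 4 gives > 100 ug/mL, a limit and not a number. The steps to compound 4 from compound 1, compound 2 and compound 3 cannot be read, and the set stays at one ceiling: the limit of > 100 ug/mL in this assay, at which 4 of the 4 values shown sit. The compounds shown leave open whether any change on the shared core gives a readable value.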